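The source may report more compounds than this note shows. Statements on the series, on what has been measured and on what is new or still open speak of the compounds shown alone.

Working notes on the series. Compound 1 `COc1cc(-c2nnc(SCC(=O)c3ccc(C(F)(F)F)cc3)n2N)cc(OC)c1OC` carries 4-(trifluoromethyl)phenyl on the carbonyl carbon of the side chain; in a functional assay on HeLa cells (Homo sapiens) for antiproliferative activity, read by MTT assay, with a stated time of 48 h (on this read-out higher numbers stand for weaker inhibition and lower numbers for stronger inhibition), compound 1 gives 3380 nM, the lowest of the two numbers recorded. Compound 2 `COc1ccc(C(=O)CSc2nnc(-c3cc(OC)c(OC)c(OC)c3)n2N)cc1` gives 17400 nM in this assay, a 5.1-fold higher number from compound 1 to compound 2 (0.71 log units; beyond the scatter) for methoxy in place of trifluoromethyl on an aromatic carbon. Compound 3 `COc1cc(-c2nnc(SCC(=O)Nc3ccccc3C)n2N)cc(OC)c1OC` reaches only a limit of this assay, > 100000 nM, and no number is recorded for it; the limit of > 100000 nM in this assay, at which 1 of the 3 values shown sits, marks that limit. The steps of an at least 29-fold higher number from compound 1 to compound 3 (1.47 log units; beyond the scatter) and an at least 5.7-fold higher number from compound 2 to compound 3 (0.75 log units; beyond the scatter) both put (2-methylphenyl)amino in place of an aromatic group on the carbonyl carbon, and both move to weaker inhibition.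

Compound 4 `COc1cc(-c2nnc(SCC(=O)NCc3ccc(C)cc3)n2N)cc(OC)c1OC` is not yet measured. Compared with compound 1 the change is (4-methylbenzyl)amino in place of 4-(trifluoromethyl)phenyl on a carbonyl carbon. This again replaces the aromatic group on the carbonyl carbon with an amino group, so the steps from compound 1 and compound 2 to compound 3 bear on it most directly; since (4-methylbenzyl)amino is not (2-methylphenyl)amino, a smaller loss cannot be excluded. A step of an 18-fold higher number from compound 1 to compound 4 (1.25 log units; beyond the scatter) toward weaker inhibition is expected. Compound 4 is therefore estimated at 60000 nM in this assay, within 15000 nM to 300000 nM, with a fair chance that only a limit is reported.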

Compound 4, half-maximal inhibitory concentration: > 100000 nM
Compound 4 gave a limit, no number (the forecaster's own chance of this, stated with the estimate: 45%); at least 1.6-fold (0.22 log units) between middle value and limit.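

In this assay compound 4 also gives a limit and not a number, so a second amide-type side chain on the carbonyl carbon falls outside the readable range: the limit of > 100000 nM in this assay, at which 2 of the 4 values shown sit.

The steps of an at least 29-fold higher number from compound 1 to compound 4 (1.47 log units; beyond the scatter) and an at least 5.7-fold higher number from compound 2 to compound 4 (0.75 log units; beyond the scatter) show that the loss at this position is not confined to (2-methylphenyl)amino, as it recurs with (4-methylbenzyl)amino, which brings 1 hydrogen-bond donor where 4-(trifluoromethyl)phenyl has 0. Going by these compounds, the step from compound 3 to compound 4 cannot be read, as both are limits, so the two amino groups cannot be ranked and the effect of 4-methylbenzyl in place of 2-methylphenyl on the amide-type nitrogen remains unknown.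

On these data alone, it remains open whether a small group such as methylamino, or a cyclic amine such as morpholine, on the carbonyl carbon would return a number in this assay. Among the aromatic groups on that carbon, it is also open whether 4-chlorophenyl or unsubstituted phenyl would extend the difference seen with 4-(trifluoromethyl)phenyl and 4-methoxyphenyl.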